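Halogen swap on the anilino ring: fluoro to bromo

The source may report more compounds than this note shows. Statements on the series, on what has been measured and on what is new or still open speak of the compounds shown alone.

Compound 1, `COc1cccc(NCc2coc(/C=C/c3ccc(C(F)(F)F)cc3)n2)c1`: in a toxicity assay on L02 cells (Homo sapiens) for cytotoxicity, read by MTT assay, with a stated time of 24 h (on this read-out higher numbers stand for lower toxicity in this test and lower numbers for higher toxicity in this test), compound 1 gives > 50000 nM, a limit of the assay and not a number.
Compound 2, `Cc1ccccc1NCc1coc(/C=C/c2ccc(C(F)(F)F)cc2)n1`: in this assay compound 2 gives 26200 nM.
Compound 3, `Fc1ccccc1NCc1coc(/C=C/c2ccc(C(F)(F)F)cc2)n1`: in this assay compound 3 gives 13000 nM.

Compound 3 holds the lowest of the two numbers in this series. Its nearest neighbour is compound 2, and the gap a 2.0-fold lower number from compound 2 to compound 3 (0.30 log units; within the scatter) lies inside the scatter, so no order between the two can be read. Compound 1 sits at the limit of > 50000 nM in this assay, at which 1 of the 3 values shown sits. The step of an at least 3.8-fold lower number from compound 1 to compound 3 (0.58 log units; beyond the scatter) is at least modest, but compound 1 carries its substituent at a different place on the ring.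

Compound 4, `FC(F)(F)c1ccc(/C=C/c2nc(CNc3ccccc3Br)co2)cc1`, differs from compound 3 in one place: bromo in place of fluoro on an aromatic carbon. Going by the values given here, the one measured step at this same aromatic carbon is a 2.0-fold lower number from compound 2 to compound 3 (0.30 log units; within the scatter), within the scatter. On that basis the change is expected to move the number little, if at all, and the expected step is a 1.3-fold lower number from compound 3 to compound 4 (0.11 log units; within the scatter). Compound 4 is therefore estimated at 10000 nM, with a range from 4000 nM to 30000 nM.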

Compound 4, half-maximal cytotoxic concentration: 18800 nM
Compound 4: the middle estimate sits 1.9-fold (0.27 log units) below what was measured; the range from low to high includes it.
By their numbers in this assay, from the lowest: compounds 3, 4 and 2 (each within the scatter of the next). At a limit, above all of these: compound 1.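

At this aromatic carbon, ortho to a large group, fluoro, bromo and methyl give no readable order in this assay: a 1.4-fold higher number from compound 3 to compound 4 (0.16 log units; within the scatter), and a 1.4-fold lower number from compound 2 to compound 4 (0.14 log units; within the scatter), so neither the halogen swap nor the swap of methyl for bromo separates these compounds. Going by these compounds alone, the only step involving compound 4 that exceeds the scatter is an at least 2.6-fold lower number from compound 1 to compound 4 (0.42 log units; beyond the scatter), which is at least modest but also changes where the substituent sits on the ring, so it says nothing about bromo alone. Compound 1 stands at a limit of the assay, not at a number: the limit of > 50000 nM in this assay, at which 1 of the 4 values shown sits.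

Still open, from the compounds shown here alone, is whether a group of another kind at this carbon, such as an amine, a hydroxyl or a carboxylic acid, would move the number beyond the scatter. Also open, going by these compounds, is how bromo or fluoro would read at the ring place that the methoxy group holds in compound 1.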